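Furan-2-yl for thiophen-2-yl on a weakly cytotoxic compound

A few compounds are considered here, and "the series" means these few. Any claim that something is new, unique, unknown or untested is made for them only; others in the source may bear on it.

Among the compounds with values here, in a functional assay on HL-60 cells (Homo sapiens) for cytotoxicity, read by XTT assay, with a stated time of 6 days (a higher number here means a weaker inhibitor, a lower number a stronger inhibitor), compound 2 `c1csc(Sc2c[nH]c3ncnc(-c4cccs4)c23)c1` gives 21100 nM, the only actual number so far. Compound 1 `CN(C)c1ncnc2[nH]cc(Sc3cccs3)c12` reads > 25000 nM in this assay, which is a limit and not a number.

Compound 3 `c1coc(-c2ncnc3[nH]cc(Sc4cccs4)c23)c1` has furan-2-yl in place of thiophen-2-yl on an aromatic carbon of the shared core: furan-2-yl in place of thiophen-2-yl on an aromatic carbon. The swap exchanges one five-membered aromatic ring with 1 hetero atom for another.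

Within the data shown here, only one measured step bears on this place, thiophen-2-yl in place of dimethylamino: an at least 1.1-fold lower number from compound 1 to compound 2 (0.07 log units; that floor lies within the scatter). Its size is tied to the limit of > 25000 nM in this assay, at which 1 of the 2 values shown sits, so it offers only a weak guide. Given that small step, no change beyond the scatter is expected, and the estimated step is a 1.2-fold lower number from compound 2 to compound 3 (0.09 log units; within the scatter). For compound 3 the expected value is 17000 nM, with an estimated range of 6000 nM to 25000 nM.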

Compound 3, half-maximal inhibitory concentration: 7630 nM
Estimate against measurement, compound 3: 2.2-fold (0.35 log units) above; low and high end bracket the measured number.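

In this assay, this position tells two five-membered aromatic rings apart: furan-2-yl in place of thiophen-2-yl gives a 2.8-fold lower number from compound 2 to compound 3 (0.44 log units; beyond the scatter). The two groups match in heavy-atom count, hydrogen-bond donors and acceptors, and charge, and differ in carrying oxygen rather than sulfur, so these counts alone do not predict the result. Furan-2-yl in place of dimethylamino gives an at least 3.2-fold lower number from compound 1 to compound 3 (0.51 log units; beyond the scatter), the first step at this position to clear the scatter, although its size is only a floor: the limit of > 25000 nM in this assay, at which 1 of the 3 values shown sits.

With only three groups shown at this position, it remains open whether a phenyl ring or a carboxylic acid there would give a lower or higher number. The thiophene linked through sulfur stays the same throughout, so it is also unknown whether the furan-2-yl step would hold with an amine in its place.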